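Changing the aromatic group on the carbonyl carbon

This account rests on a few compounds, and the source may have more. Where it says the series, first, only, none or still open, it means among the compounds named here.

Measured compounds:
compound 1 `Cc1ccccc1NC(=S)N1CCc2c(sc(NC(=O)c3ccccc3Cl)c2C(N)=O)C1` gives 11700 nM
compound 2 `NC(=O)c1c(NC(=O)c2ccccc2I)sc2c1CCN(C(=S)Nc1ccccc1Cl)C2` gives 17500 nM
compound 3 `NC(=O)c1c(NC(=O)c2ccccc2C(F)(F)F)sc2c1CCN(C(=S)Nc1ccccc1Cl)C2` gives 21900 nM

In a functional assay on MKN-74 cells (Homo sapiens) for antiproliferative activity, with a stated time of 24 h (a lower number here means a stronger inhibitor, a higher number a weaker inhibitor), compound 3 shows the highest number of the three, yet its gaps to compound 2 and to compound 1 both lie within the scatter, so the three cannot be ranked. Within the data shown here, the only single-place step measured, a 1.3-fold higher number from compound 2 to compound 3 (0.10 log units; within the scatter), changes a group on the aromatic ring attached to the carbonyl carbon and stays within the scatter. Compound 4 `NC(=O)c1c(NC(=O)c2cccc([N+](=O)[O-])c2)sc2c1CCN(C(=S)Nc1ccccc1Cl)C2` changes that same aromatic group: 3-nitrophenyl in place of 2-(trifluoromethyl)phenyl on a carbonyl carbon. Among the measured compounds shown here, no measured step covers this particular exchange, so the one step at this place is the only guide, and it suggests no change beyond the scatter. Compound 4 is therefore expected at 18000 nM (range 6000 nM to 50000 nM), an expected 1.2-fold lower number from compound 3 to compound 4 (0.09 log units; within the scatter).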

Compound 4, half-maximal inhibitory concentration: 8850 nM
The estimate for compound 4 lay 2.0-fold (0.31 log units) above the measured number, and the stated range covers the measured number.
By their numbers in this assay, from the lowest: compounds 4, 1, 2 and 3 (each within the scatter of the next, the first and the last beyond it).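

In this assay, the aromatic group on the carbonyl carbon can move the number beyond the scatter: 3-nitrophenyl in place of 2-(trifluoromethyl)phenyl gives a 2.5-fold lower number from compound 3 to compound 4 (0.39 log units; beyond the scatter) as a modest step. The same group in place of 2-iodophenyl gives a 2.0-fold lower number from compound 2 to compound 4 (0.30 log units; within the scatter) and so stays within the scatter, which leaves the effect resting on a single exchange. No measurement available here bears on why this exchange shifts the number.

Still open, from the compounds shown here alone, is how 2-nitrophenyl or 3-aminophenyl would compare on the same carbonyl carbon, which would help separate the role of the nitro group from that of its place on the ring.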